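Changing the Amide Substituent of Compound 1

This account rests on a few compounds, and the source may have more. Where it says the series, first, only, none or still open, it means among the compounds named here.

Measured so far:
compound 1 `COCCNC(=O)c1cc2cccc(OC)c2oc1=N` — 15%
compound 2 `CCC(CO)NC(=O)c1cc2cc(Cl)ccc2oc1=N` — 0%

In an assay on HeLa cells for displacement of a labelled ligand from adenosine receptor A3 (Homo sapiens), read by scintillation counting, with a stated time of 180 min, tested at 10 uM (a higher number here means more inhibition at the concentration tested (going by the name of the read-out), a lower number less inhibition), compound 1 gives 15%, the higher of the two numbers shown, while compound 2 gives 0%, a gap beyond the usual scatter. Compound 3 `COc1cccc2cc(C(=O)NC(CO)(CO)CO)c(=N)oc12` has not yet been measured. It differs from compound 1 in one place: 2-hydroxy-1,1-bis(hydroxymethyl)ethyl in place of 2-methoxyethyl on an amide-type nitrogen. No measured pair shows this change, so nothing shown points to its effect, and the starting number of compound 1 is already modest. The step expected is a number 7 percentage points lower from compound 1 to compound 3 (within the scatter), small and downward or none beyond the scatter. Compound 3 is estimated at 8%, within 0% to 25%.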

Compound 3, a percentage reported as inhibition, at one concentration (the size of the read-out at that concentration, not a potency): 18%
Beside the measured number, compound 3's estimate is 10 percentage points below it; measured number inside the range.
By their numbers in this assay, from the lowest: compound 2; then compounds 1 and 3 (each within the scatter of the next).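

In this assay, the swap of 2-methoxyethyl for 2-hydroxy-1,1-bis(hydroxymethyl)ethyl on the amide-type nitrogen gives a number 3 percentage points higher from compound 1 to compound 3 (within the scatter). Within the data shown here, this is the first measured pair for this position, and it shows that a larger group with more hydrogen-bond donors can sit there with no difference beyond the scatter. Nothing available explains why the number holds. Still open, on these data alone, is whether an amine, a carboxylic acid or a phenyl ring on this nitrogen would shift the number beyond the scatter.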